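Ring substitution on the shared core and agonist potency

The compounds below may be only part of what the source reports. "The series", "measured", "known", "first", "only" and "open" are said of these compounds alone.

Compound 1 `c1cncc(N2CC[C@H]3CN[C@H]3C2)c1`: 48 nM
Compound 2 `c1cncc(N2CC[C@@H]3CN[C@@H]3C2)c1`: 260 nM
Compound 3 `COc1ccc(N2CC[C@@H]3CN[C@@H]3C2)cn1`: 2400 nM

In a functional assay on HEK293 cells for agonist activity at Neuronal acetylcholine receptor; alpha3/beta4 (Homo sapiens), read by FLIPR (on this read-out higher numbers stand for an effect only at larger amounts of compound and lower numbers for an effect already at smaller amounts), compound 2 gives 260 nM and stands second highest of the three numbers. The step of a 5.4-fold higher number from compound 1 to compound 2 (0.73 log units; beyond the scatter) rests on (the fact that compounds 1 and 2 differ only in the configuration as drawn). The step of a 9.2-fold higher number from compound 2 to compound 3 (0.97 log units; beyond the scatter) shows that a group entering on the aromatic ring raises the number. Compound 4 `N/C(=N/O)c1cncc(N2CC[C@@H]3CN[C@@H]3C2)c1` differs from compound 2 by a group of 4 heavy atoms (1 carbon, 2 nitrogen, 1 oxygen; no ring) in place of a hydrogen atom, on an aromatic carbon. The step from compound 2 to compound 3 is the only measured one that bears on a substituent entering the ring, and it was modest; a rise of similar order is therefore expected for compound 4, though the group differs. Compound 4 is estimated at 900 nM, in the range 250 nM to 3500 nM, a step of a 3.5-fold higher number from compound 2 to compound 4 (0.54 log units; beyond the scatter).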

Compound 4, half-maximal effective concentration: 5700 nM
Compound 4: the middle estimate sits 6.3-fold (0.80 log units) below what was measured, outside the stated range (above it).
By their numbers in this assay, from the lowest: compound 1; then compound 2; then compound 3; then compound 4.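

The step of a 22-fold higher number from compound 2 to compound 4 (1.34 log units; beyond the scatter) shows that in this assay this aromatic carbon, two atoms from the ring nitrogen, can carry a large penalty when this group replaces hydrogen. That step exceeds the one seen with methoxy, a 9.2-fold higher number from compound 2 to compound 3 (0.97 log units; beyond the scatter), so a substituent on this aromatic ring can raise the number further than compound 3 indicated. Nothing measured here explains this rise.

The compounds shown leave open whether a smaller group at this carbon, such as an amine or a single fluorine, would raise the number as far. They also leave open how the same group would behave on the core of compound 1.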